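Swapping 2-fluorobenzyl for 3-bromobenzyl on a shared core

The source may report more compounds than this note shows. Statements on the series, on what has been measured and on what is new or still open speak of the compounds shown alone.

In a functional assay on HeLa cells (Homo sapiens) for antiproliferative activity, read by MTT assay, with a stated time of 24 h (a higher number here means a weaker inhibitor, a lower number a stronger inhibitor), compound 1 `c1ccc(CSc2nnc(-c3ccc4c(c3)OCCO4)n2-c2ccccc2)cc1` gives 32800 nM. Compound 2 `Fc1ccccc1CSc1nnc(-c2ccc3c(c2)OCCO3)n1-c1ccccc1` gives 24300 nM, which places it level with compound 1 once the ordinary scatter of repeat measurements is allowed for. Compound 3 `Brc1cccc(CSc2nnc(-c3ccc4c(c3)OCCO4)n2-c2ccccc2)c1` has not yet been measured. It carries 3-bromophenyl in place of 2-fluorophenyl on a saturated chain carbon bound to a sulfur. Within the data shown here, only one measured step bears on this change: fluoro in place of hydrogen on an aromatic carbon, a 1.3-fold lower number from compound 1 to compound 2 (0.13 log units; within the scatter), which lies within the scatter. That step involves no bromine, so it is weak evidence, and nothing measured points to a shift in either direction. The expected result is therefore no change beyond the scatter, a 1.1-fold lower number from compound 2 to compound 3 (0.02 log units; within the scatter). For compound 3 the estimated value in this assay is 23000 nM, within a range of 9000 nM to 55000 nM.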

Compound 3, half-maximal inhibitory concentration: 44200 nM
Compound 3: the middle estimate sits 1.9-fold (0.28 log units) below what was measured; the measured number falls inside the stated range.
By their numbers in this assay, from the lowest: compounds 2, 1 and 3 (each within the scatter of the next).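

In this assay, the ring on a saturated chain carbon bound to a sulfur has now carried a bromine as well as a fluorine, and the swap between the two substituted rings gives a 1.8-fold higher number from compound 2 to compound 3 (0.26 log units; within the scatter). Set against the plain benzyl group, bromo in place of hydrogen gives a 1.3-fold higher number from compound 1 to compound 3 (0.13 log units; within the scatter), so benzyl, 2-fluorobenzyl and 3-bromobenzyl cannot be told apart in this assay. No measurement shown here offers an explanation for these numbers.

The step to 3-bromobenzyl alters both the halogen and its place on the ring, and the compounds shown cannot separate those two changes. On these data alone, whether an amine or a carboxylic acid on this ring, or a longer chain in place of the benzyl group, would move the number beyond the scatter remains open.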